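The source may report more compounds than this note shows. Statements on the series, on what has been measured and on what is new or still open speak of the compounds shown alone.

Notes on the benzothiazole-bearing aminopyrimidine series. Cytotoxicity is read in an ADME assay on cells (Homo sapiens) for cytotoxicity, read by polymerase chain reaction, with a stated time of 3 days; a lower number here means that less compound is tolerated, a higher number that more compound is tolerated. Compound 1 `CNc1ccc2sc(-c3c(Cl)nc(N)nc3N[C@@H]3C[C@H](CO)[C@@H](O)[C@H]3O)nc2c1` gives 20000 nM in this assay. Compound 2 `CCc1nc(N(C)C)nc(N[C@@H]2C[C@H](CO)[C@@H](O)[C@H]2O)c1-c1nc2ccccc2s1` gives only > 25000 nM in this assay, which is a limit and not a number (the limit of > 25000 nM in this assay, at which 1 of the 3 values shown sits). Compound 3 `CCOC(=O)NCCNc1nc(C)c(-c2nc3ccccc3s2)c(N[C@@H]2C[C@H](CO)[C@@H](O)[C@H]2O)n1` gives 12000 nM in this assay, the lowest of the two numbers, with compound 1 nearest at a gap within the scatter. Compound 4 `Cc1nc(NCc2cccnc2)nc(N[C@@H]2C[C@H](CO)[C@@H](O)[C@H]2O)c1-c1nc2ccccc2s1` is not yet measured. Its change from compound 3 is pyridin-3-yl in place of ((ethoxycarbonyl)amino)methyl on a saturated chain carbon bound to a nitrogen on an aromatic ring. For the measured compounds named here, no measured pair differs in one place, so no step of this kind is known. With the two numbers within the scatter of each other and the third value a limit, the step in this assay is expected to be none beyond the scatter, in neither direction. Compound 4 is estimated at 15000 nM, between 6000 nM and 25000 nM, an expected step of a 1.3-fold higher number from compound 3 to compound 4 (0.10 log units; within the scatter).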

Compound 4, half-maximal cytotoxic concentration: 5000 nM
Beside the measured number, compound 4's estimate is 3.0-fold (0.48 log units) above it; the whole stated range lies above it.
By their numbers in this assay, from the lowest: compound 4; then compounds 3 and 1 (each within the scatter of the next). At a limit, above all of these: compound 2.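

Replacing ((ethoxycarbonyl)amino)methyl with pyridin-3-yl on a saturated chain carbon bound to a nitrogen on an aromatic ring gives, in this assay, a 2.4-fold lower number from compound 3 to compound 4 (0.38 log units; beyond the scatter), with less compound tolerated. For the compounds shown here, this is the first step that can be read, and it shows that the group at this place bears on the read-out, although modestly. Nothing measured here accounts for the step.

This single step does not separate the effect of the aromatic ring from that of losing the ((ethoxycarbonyl)amino)methyl group. A phenyl ring, a morpholine or a free primary amine at the same place would be needed to tell these apart.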